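Replacing a Urea Arm with an Amide: Expected Activity

The compounds below may be only part of what the source reports. "The series", "measured", "known", "first", "only" and "open" are said of these compounds alone.

In a functional assay on BT-549 cells (Homo sapiens) for inhibition, read by sulforhodamine B assay, with a stated time of 48 h, tested at 0.1 uM (a higher number here means a weaker effect of the compound at the concentration tested, a lower number a stronger effect), compound 3 `COc1cc(Cl)cc(-c2nn(-c3cccc(NC(=O)Nc4ccc(Cl)c(Cl)c4)c3)cc2-c2ccncc2)c1` gives 98%, the highest of the three numbers, though both others lie within the scatter of it: compound 1 `O=C(Nc1cccc(-n2cc(-c3ccncc3)c(-c3cc(O)cc(Cl)c3)n2)c1)Nc1ccc(Cl)c(Cl)c1` gives 93%, and compound 2 `COc1cc(Cl)cc(-c2nn(-c3cccc(NC(=O)Nc4cc(C(F)(F)F)cc(C(F)(F)F)c4)c3)cc2-c2ccncc2)c1` gives 89%. Compound 4 `COc1cc(Cl)cc(-c2nn(-c3cccc(NC(=O)c4cccc(C(F)(F)F)c4)c3)cc2-c2ccncc2)c1` differs from compound 3 by 3-(trifluoromethyl)phenyl in place of (3,4-dichlorophenyl)amino on a carbonyl carbon. Within the data shown here, the one measured step, a number 5 percentage points higher from compound 1 to compound 3 (within the scatter), concerns a methyl on an oxygen elsewhere and does not touch this change. Compound 2 and compound 3 share the rest of the structure, and their values lie within the scatter of each other. With nothing pointing to a shift, compound 4 is expected to show a number 5 percentage points lower from compound 3 to compound 4 (within the scatter), and its estimated value is 93%, in a range from 80% to 102%.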

Compound 4, a percentage reported as activity, at one concentration (the size of the read-out at that concentration, not a potency): 94%
Compound 4: the middle estimate sits 1 percentage points below what was measured; the range from low to high includes it.
By their numbers in this assay, from the lowest: compounds 2, 1, 4 and 3 (each within the scatter of the next).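

Going from the urea to the amide, with 3-(trifluoromethyl)phenyl in place of (3,4-dichlorophenyl)amino on the carbonyl carbon, gives a number 4 percentage points lower from compound 3 to compound 4 (within the scatter) in this assay. So this swap, which also removes the hydrogen-bond donor of the group that leaves, produces no change beyond the scatter. Nothing shown here offers a reason for this result. The compounds shown leave open what a carbonyl carbon bearing a longer alkyl chain or an amine-carrying chain would give, and whether such a group would move the number beyond the scatter.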